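Adding Fluoromethyl to Compound 3

The compounds below may be only part of what the source reports. "The series", "measured", "known", "first", "only" and "open" are said of these compounds alone.

In a physicochemical assay for lipophilicity, at pH 7.4 (a higher number here means a more lipophilic compound, a lower number a more polar compound), the measured compounds stand as follows:
- compound 1 `CNC(=O)c1cc(C(N)=O)cc2c1O[C@H](CF)[C@H]2c1ccccc1` gives 2.9
- compound 2 `CNC(=O)c1cc(C(=O)N[C@@H]2C[C@H]2C)cc2c1O[C@H](CF)[C@H]2c1ccccc1` gives 4.5
- compound 3 `CNC(=O)c1cc(C(=O)NC)c2c(c1)[C@H](c1ccccc1)CO2` gives 3.2

On these numbers compound 3 lies within the scatter of compound 1 and well under compound 2. The next compound to be considered is compound 4 `CNC(=O)c1cc(C(=O)NC)c2c(c1)[C@H](c1ccccc1)[C@@H](CF)O2` which differs from compound 3 by fluoromethyl in place of hydrogen on a saturated ring carbon next to the ring oxygen and next to the ring atom that bears a phenyl group.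

Among the compounds with values here, the only measured step between compounds that differ in one place is large: a number 1.60 log units higher from compound 1 to compound 2 (beyond the scatter) but it concerns an amide-type nitrogen and not this ring carbon, so its size does not carry over. Compound 1 carries fluoromethyl and compound 3 does not, but the two also differ elsewhere, and their values in this assay lie within the scatter of each other. That pair cannot isolate the change.

Starting from compound 3 at 3.2 and with no measured step for this change, a small rise is expected. The expected step is a number 0.30 log units higher from compound 3 to compound 4 (within the scatter) and would be modest in size. For compound 4 the estimate is 3.5 with an expected range from 3.1 to 3.9 in this measurement.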

Compound 4, distribution coefficient: 3.3
Estimate against measurement, compound 4: 0.20 log units above; the range from low to high includes it.
By their numbers in this assay, from the lowest: compounds 1, 3 and 4 (each within the scatter of the next, the first and the last beyond it); then compound 2.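

In this assay, within the data shown here, fluoromethyl in place of hydrogen on a saturated ring carbon, next to the ring oxygen and next to the ring atom that bears a phenyl group, gives a number 0.10 log units higher from compound 3 to compound 4 (within the scatter), the first reading of this change on its own at this position. With fluoromethyl present throughout, compound 4 also links to both earlier fluoromethyl compounds through the amide-type nitrogen: there is a number 0.40 log units higher from compound 1 to compound 4 (beyond the scatter) for methyl in place of hydrogen, and a number 1.20 log units lower from compound 2 to compound 4 (beyond the scatter) for methyl in place of 2-methylcyclopropyl, so both nitrogen steps lie beyond the scatter while the ring-carbon step lies within it. No measurement shown here accounts for the size of any of these steps.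

The compounds shown leave open whether a different group on this ring carbon, such as a longer chain like propyl, an amine or a carboxylic acid, would also stay within the scatter of compound 3 in this assay. They also leave open whether fluoromethyl would give a similar step with another group on the amide-type nitrogen, such as 2-methylcyclopropyl.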